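The compounds below may be only part of what the source reports. "The series", "measured", "known", "first", "only" and "open" are said of these compounds alone.

Of the compounds shown here, three have been read in a functional assay on A-375 cells (Homo sapiens) for inhibition, read by CCK-8 assay, with a stated time of 72 h, tested at 2 uM; on this read-out lower numbers stand for less inhibition of growth and higher numbers for more inhibition of growth at the one concentration tested. Compound 1 (`CCc1ccc(SCc2ccc(/C=C/C(=O)Nc3ccccc3N)cc2)cc1`) gives 5.27% there, compound 2 (`CCc1ccc(SCc2ccc(C(=O)Nc3ccccc3N)cc2)cc1`) gives 19.6% and compound 3 (`Nc1ccccc1NC(=O)/C=C/c1ccc(CSc2ccc(F)cc2)cc1`) gives 28.8% in the same test. On these numbers, compound 2 lies within the usual scatter of compound 3 and clearly higher than compound 1.

Compound 4 (`Nc1ccccc1NC(=O)c1ccc(CSc2ccc(Br)cc2)cc1`) keeps the core of compound 2 and changes one group: bromo in place of ethyl on an aromatic carbon (bromo in place of ethyl on an aromatic carbon, para to a large group). Among the measured compounds shown here, only one measured step bears on this change. It is a number 23.5 percentage points higher from compound 1 to compound 3 (beyond the scatter) with fluoro in place of ethyl, a modest move beyond the scatter. That step has two limits as a guide: it was measured on the core shared by those two compounds, which is not the core of compound 2, and it involves fluoro rather than bromo. For the measured compounds named here, no bromo compound has yet been measured.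

An upward move is therefore expected, though a smaller one than that single precedent, and the estimated change is a number 14.4 percentage points higher from compound 2 to compound 4 (beyond the scatter) at this stage. For compound 4 the estimate is 34% with an expected range from 18% to 52% in this assay.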

Compound 4, percent growth inhibition at one concentration: 4.35%
The estimate for compound 4 lay 29.7 percentage points above the measured number; measured number below the stated range.
By their numbers in this assay, from the lowest: compounds 4 and 1 (each within the scatter of the next); then compounds 2 and 3 (each within the scatter of the next).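

In this assay, the change from 4-ethylphenyl to 4-bromophenyl on the core of compound 2 lowers the reading, with a number 15.3 percentage points lower from compound 2 to compound 4 (beyond the scatter). Among the compounds shown here, the only earlier change at this place went the other way, with a number 23.5 percentage points higher from compound 1 to compound 3 (beyond the scatter), so replacing ethyl here does not move the number in one direction across the two pairs of compounds. These two steps differ in both the incoming halogen and the core, and no information is available to explain the fall seen with bromo or the opposite direction of the two steps.

The compounds shown leave open whether the halogen or the core sets the direction, a question that fluoro on the core of compound 2 and bromo on the core of compound 1 could settle. They also leave open how an amine, a carboxylic acid or a longer chain in place of ethyl would read on either core, and whether any of these readings would hold beyond the single concentration tested here.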